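The source may hold more compounds than are shown below. What is called first, only, known or untested is meant among the compounds shown, and "the series" means these compounds.

Compound 1 `CN1Cc2c(NC(=O)OCc3ccccc3)cccc2C(c2ccccc2)C1` gives 25 mg/kg in a functional assay on the whole organism for inhibition of sodium-dependent dopamine transporter (Mus musculus); on this read-out higher numbers stand for an effect only at larger amounts of compound and lower numbers for an effect already at smaller amounts. Compound 2 `CCNCC(=O)Nc1cccc2c1CN(C)CC2c1ccccc1` gives about 60 mg/kg in this assay, the higher of the two numbers recorded; the step of a 2.4-fold higher number from compound 1 to compound 2 (0.38 log units; beyond the scatter) describes that difference. Compound 3 `CCCCNCC(=O)Nc1cccc2c1CN(C)CC2c1ccccc1` differs from compound 2 by ethyl in place of hydrogen on a saturated chain carbon, two bonds along the chain from an amine nitrogen. Among the compounds with values here, no measured step touches this part of the molecule, so the one known step, which concerns another position, is of little use as a guide, and a change no larger than the usual scatter is expected. Compound 3 is therefore estimated at 60 mg/kg, with a range of 30 mg/kg to 120 mg/kg, meaning an expected step of no change at the digits printed from compound 2 to compound 3 (within the scatter).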

Compound 3, dose for half-maximal effect: 25 mg/kg
Compound 3: middle estimate off by 2.4-fold (0.38 log units), on the high side; measured number below the stated range.
By their numbers in this assay, from the lowest: compounds 1 and 3 (each within the scatter of the next); then compound 2.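

Going from ethylamino to butylamino on this chain does register in this assay: the record shows a 2.4-fold lower number from compound 2 to compound 3 (0.38 log units; beyond the scatter), so the effect appears at smaller amounts of compound and this position is not silent. With butylamino, swapping benzyloxy on the carbonyl carbon for (butylamino)methyl gives no change at the digits printed from compound 1 to compound 3 (within the scatter), unlike the ethylamino case. Nothing in the available data explains the shift. On these data alone, whether the trend continues with a longer chain such as hexylamino remains open. So does the outcome with propylamino or a ring amine such as piperidine.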